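The source may hold more compounds than are shown below. What is called first, only, known or untested is meant among the compounds shown, and "the series" means these compounds.

In a functional assay, read by fluorescence and spectrophotometry, with a stated time of 1 h (on this read-out lower numbers stand for an effect already at smaller amounts and higher numbers for an effect only at larger amounts of compound), compound 1 (`CCCCCCCCCCCCS(=O)(=O)/C=C/c1ccc(O)c(O)c1`) gives 8500 nM, compound 2 (`C=CCCCCCCCS(=O)(=O)/C=C/c1ccc(O)c(O)c1`) gives 6900 nM and compound 3 (`O=S(=O)(/C=C/c1ccc(O)c(O)c1)CCC1CCCCC1`) gives 9800 nM, so compound 3 lies within the scatter of both others. Compound 4 (`CCCCCS(=O)(=O)/C=C/c1ccc(O)c(O)c1`) has propyl in place of cyclohexyl on a saturated chain carbon, two bonds along the chain from a sulfonyl sulfur. Two measured chain changes bear on this: a 1.2-fold lower number from compound 1 to compound 2 (0.09 log units; within the scatter) and a 1.4-fold higher number from compound 2 to compound 3 (0.15 log units; within the scatter), both within the scatter. Within the data shown here, no measured compound has a chain this short, so the range stays wide. No change beyond the scatter is expected in this assay, and the estimated step is a 1.1-fold higher number from compound 3 to compound 4 (0.05 log units; within the scatter). For compound 4 the expected value is 11000 nM, with an estimated range of 4500 nM to 30000 nM.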

Compound 4, half-maximal effective concentration: 8100 nM
Beside the measured number, compound 4's estimate is 1.4-fold (0.13 log units) above it, and the stated range covers the measured number.
By their numbers in this assay, from the lowest: compounds 2, 4, 1 and 3 (each within the scatter of the next).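

In this assay, propyl in place of cyclohexyl on a saturated chain carbon, two bonds along the chain from a sulfonyl sulfur, gives a 1.2-fold lower number from compound 3 to compound 4 (0.08 log units; within the scatter) and so the ring can go from this position without a step beyond the scatter. Hydrogen in place of but-3-en-1-yl on a saturated chain carbon, five bonds along the chain from a sulfonyl sulfur, gives a 1.2-fold higher number from compound 2 to compound 4 (0.07 log units; within the scatter) and hydrogen in place of heptyl at that place gives a 1.0-fold lower number from compound 1 to compound 4 (0.02 log units; within the scatter) so the shorter chain also stays within the scatter of both longer ones. Nothing available gives a reason for this lack of separation.

Open, on these data alone, is whether a terminal amine or carboxylic acid on the chain would give a step beyond the scatter. Also open, as far as these compounds go, is whether a methyl or ethyl group in place of the pentyl chain would do so.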